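This account rests on a few compounds, and the source may have more. Where it says the series, first, only, none or still open, it means among the compounds named here.

Compound 3, `COc1ccc(-c2cc3ccccc3nc2/C=C/C(=O)c2cccs2)cc1`, is the strongest inhibitor among the three compounds measured in a functional assay on MCF7 cells (Homo sapiens) for antiproliferative activity, read by XTT assay, with a stated time of 72 h (a higher number here means a weaker inhibitor, a lower number a stronger inhibitor), where compound 3 gives 1030 nM. Compound 1, `COc1ccc(-c2cc3ccccc3nc2/C=C/C(=O)c2c(OC)cccc2OC)cc1`, gives 4520 nM in this assay, and compound 2, `COc1ccc(-c2cc3ccccc3nc2/C=C/C(=O)c2ccc(N)cc2)cc1`, gives 6920 nM. The two steps that reach compound 3 both move in the same direction: a 4.4-fold lower number from compound 1 to compound 3 (0.64 log units; beyond the scatter) and a 6.7-fold lower number from compound 2 to compound 3 (0.83 log units; beyond the scatter). The step between the other two, a 1.5-fold higher number from compound 1 to compound 2 (0.18 log units; within the scatter), is small.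

Compound 4, `COc1ccc(-c2cc3ccccc3nc2/C=C/C(=O)c2cnc(N)nc2C)cc1`, differs from compound 3 in one place: 2-amino-4-methylpyrimidin-5-yl in place of thiophen-2-yl on a carbonyl carbon. The measured steps bear on this change only indirectly. Both replacements of the thiophen-2-yl group by a six-membered aromatic ring, in compound 1 and compound 2, went together with higher numbers, and the group entering compound 4 is again a six-membered aromatic ring and again carries an amino group, as compound 2 does. On that basis a higher number is expected for compound 4 in this assay, roughly the size of a 3.4-fold higher number from compound 3 to compound 4 (0.53 log units; beyond the scatter), though the new ring also brings two ring nitrogens and a methyl group for which no measured comparison exists. Compound 4 is therefore estimated at 3500 nM, with a range from 1200 nM to 10000 nM.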

Compound 4, half-maximal inhibitory concentration: > 10000 nM
Compound 4 ended at the assay's limit (the forecaster's own chance of this, stated with the estimate: 5%); middle value at least 2.8-fold (0.45 log units) from the limit.
By their numbers in this assay, from the lowest: compound 3; then compounds 1 and 2 (each within the scatter of the next). At a limit, above all of these: compound 4.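

In this assay compound 4 gives > 10000 nM, which is a limit of the assay and not a number: the limit of > 10000 nM in this assay, at which 1 of the 4 values shown sits.

At this place, on a carbonyl carbon, the exchange of thiophen-2-yl for 2-amino-4-methylpyrimidin-5-yl gives an at least 9.7-fold higher number from compound 3 to compound 4 (0.98 log units; beyond the scatter), so the sizes printed for compound 4 are floors and the real steps may be larger. Compound 4 also separates from a group that was already weak, with an at least 2.2-fold higher number from compound 1 to compound 4 (0.34 log units; beyond the scatter), which shows that the six-membered rings at this place do not all end at the same level. Against the other amino-bearing ring the result is less clear, with an at least 1.4-fold higher number from compound 2 to compound 4 (0.15 log units; that floor lies within the scatter), so this floor alone does not set compound 4 apart from compound 2.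

The ring nitrogens, the amino group and the methyl group all change together in compound 4, and the compounds shown do not tell which of them goes with the higher number. A plain phenyl, a pyridin-3-yl or a furan-2-yl group on the same carbonyl carbon would help to show whether the low number of compound 3 belongs to thiophen-2-yl specifically or to five-membered aromatic rings more widely.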